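Moving the fluorine on the benzyl group of compound 1

The source may hold more compounds than are shown below. What is called first, only, known or untested is meant among the compounds shown, and "the series" means these compounds.

Measured in a functional assay on MDA-MB-231 cells (Homo sapiens) for inhibition, read by MTT assay, with a stated time of 5 days; on this read-out higher numbers stand for weaker inhibition and lower numbers for stronger inhibition:
- compound 1 `Cc1cc(Nc2nc(NCc3ccccc3F)nc3[nH]ncc23)n[nH]1` gives 9850 nM
- compound 2 `Cc1cc(Nc2nc(NCc3ccccc3Cl)nc3[nH]ncc23)n[nH]1` gives 4210 nM

Compound 1, at 9850 nM in this assay, holds the higher of the two numbers. The change to compound 3 `Cc1cc(Nc2nc(NCc3ccc(F)cc3)nc3[nH]ncc23)n[nH]1` is 4-fluorophenyl in place of 2-fluorophenyl on a saturated chain carbon bound to a nitrogen on an aromatic ring with 4-fluorophenyl in place of 2-fluorophenyl on a saturated chain carbon bound to a nitrogen on an aromatic ring. Going by the values given here, only one measured step bears on this, and only loosely: a 2.3-fold lower number from compound 1 to compound 2 (0.37 log units; beyond the scatter) is a modest step for chloro in place of fluoro. Among the compounds with values here, no measured step shows this change itself, so no step beyond the scatter is expected. The estimated step is a 1.2-fold lower number from compound 1 to compound 3 (0.09 log units; within the scatter) at most a slight one. For compound 3 the expected value is 8000 nM within an estimated range from 3000 nM to 20000 nM in this read-out.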

Compound 3, half-maximal inhibitory concentration: 8410 nM
Compound 3: middle estimate off by 1.1-fold (0.02 log units), on the low side, and the stated range covers the measured number.
By their numbers in this assay, from the lowest: compounds 2, 3 and 1 (each within the scatter of the next, the first and the last beyond it).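

In this assay, moving the fluorine from 2-fluorophenyl to 4-fluorophenyl on this saturated chain carbon gives a small step (a 1.2-fold lower number from compound 1 to compound 3 (0.07 log units; within the scatter)), so this change of place does not separate compound 3 from compound 1. The comparison with the chlorinated compound also stays inside the scatter (a 2.0-fold higher number from compound 2 to compound 3 (0.30 log units; within the scatter)), although compound 1 and compound 2 do differ beyond it. Nothing measured here accounts for these numbers. As far as these compounds go, it remains open whether a nitrile or an amine on the phenyl ring, or a longer chain in place of the benzyl link, would shift the number beyond the scatter.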